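Fluoro to methoxy on an indolyl acrylonitrile series: no potency read

The compounds below may be only part of what the source reports. "The series", "measured", "known", "first", "only" and "open" are said of these compounds alone.

Measured compounds: compound 1 `COc1ccc2c(/C=C(\C#N)C(=O)c3c[nH]c4cc(OC)ccc34)c[nH]c2c1`, > 50000 nM; compound 2 `N#C/C(=C\c1cn(Cc2ccc(Cl)cc2)c2ccccc12)C(=O)c1c[nH]c2cc(F)ccc12`, > 50000 nM; compound 3 `COc1ccc2c(C(=O)/C(C#N)=C/c3c[nH]c4cc(F)ccc34)c[nH]c2c1`, > 50000 nM.

In a functional assay on MIA PaCa-2 cells (Homo sapiens) for cytotoxicity, read by WST assay, with a stated time of 24 h (on this read-out lower numbers stand for stronger inhibition and higher numbers for weaker inhibition), compound 3 gives only a limit, > 50000 nM. Compound 1 likewise gives only a limit, > 50000 nM. The change between them, (methoxy in place of fluoro on an aromatic carbon), therefore produces a step that the two limits leave unreadable from compound 3 to compound 1. Compound 2 also gives only a limit, > 50000 nM; the difference between the cores of compound 2 and compound 3 is not broken down here. All three values sit at the limit of > 50000 nM in this assay, at which 3 of the 3 values shown sit.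

Compound 4 `COc1ccc2c(C(=O)/C(C#N)=C/c3cn(Cc4ccc(Cl)cc4)c4ccccc34)c[nH]c2c1`, not yet measured, differs from compound 2 by methoxy in place of fluoro on an aromatic carbon, the same change as from compound 3 to compound 1. Since that earlier step was unreadable, the step of a number no higher from compound 2 to compound 4 (the limit leaves the size open) is expected to be unreadable as well. Compound 4 is therefore expected to give 50000 nM, most likely as a limit rather than a number.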

Compound 4, half-maximal inhibitory concentration: > 50000 nM
Compound 4 ended at the assay's limit (the forecaster's own chance of this, stated with the estimate: 80%); the middle value sits exactly at the limit.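

Compound 2 and compound 4 both stay at a limit rather than a number, so no step can be read between them: the limit of > 50000 nM in this assay, at which 4 of the 4 values shown sit.

The compounds shown leave open whether methoxy in place of fluoro changes potency at all in this assay.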